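Oxazolidinone amides: an ether swap from aryl to alkyl

This account rests on a few compounds, and the source may have more. Where it says the series, first, only, none or still open, it means among the compounds named here.

Measured compounds:
- compound 1, `O=C(CCCCCc1ccc(Br)cc1)N1CCOC1=O`, 8510 nM
- compound 2, `O=C1OCCN1C(=O)c1ccc(Oc2cccc(Cl)c2)cc1`, 7740 nM

Of the compounds shown here, two have been measured in an assay on HEK293 cells for inhibition of N-acylethanolamine-hydrolyzing acid amidase (Rattus norvegicus), read by LC-MS, with a stated time of 30 min; a lower number here means a stronger inhibitor, a higher number a weaker inhibitor. Compound 1 gives 8510 nM in this assay. Compound 2 gives 7740 nM in this assay, the lowest of the two numbers, but its gap to compound 1 lies within the scatter, so the two cannot be told apart on these data.

Compound 3, `CCC(CC)Oc1ccc(C(=O)N2CCOC2=O)cc1`, differs from compound 2 in one place: pentan-3-yl in place of 3-chlorophenyl on an oxygen on an aromatic ring. For the measured compounds named here, no measured pair shows what such a change does in this assay, so the direction of the step is open. Going by the values given here, the only guidance is that both measured compounds, with very different groups attached to the amide carbonyl, land close together in this assay, which argues against a large move in either direction. A modest loss, within or just beyond the scatter, seems most likely for compound 3.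

Compound 3 is therefore expected to give about 12000 nM in this assay, with a plausible range from 3500 nM to 45000 nM. This estimate amounts to a step of a 1.6-fold higher number from compound 2 to compound 3 (0.19 log units; within the scatter), an expected change of modest size.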

Compound 3, half-maximal inhibitory concentration: 480 nM
Compound 3: the middle estimate sits 25-fold (1.40 log units) above what was measured, and the stated range ends above it.
By their numbers in this assay, from the lowest: compound 3; then compounds 2 and 1 (each within the scatter of the next).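

In this assay, pentan-3-yl in place of 3-chlorophenyl on an oxygen on an aromatic ring brings a 16-fold lower number from compound 2 to compound 3 (1.21 log units; beyond the scatter), so this position responds strongly to the group on the oxygen, something the two earlier compounds could not show. The change also shows that an aromatic ring on this oxygen is not required for inhibition, as the entering group has no ring and compound 3 gives the lower number of the pair. No measurement shown here explains why this exchange has so large an effect.

From the compounds shown here alone, it remains open whether the gain is specific to pentan-3-yl or would also appear with another group on this oxygen, such as a cyclohexyl ring, a straight pentyl chain or a simple methyl. Going by these compounds, it is also open whether the chlorine or the aromatic ring of the departing 3-chlorophenyl group accounts for the difference, a question that a plain phenyl group on the same oxygen would help to separate.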